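Methyl on the phenyl of the shared core

A few compounds are considered here, and "the series" means these few. Any claim that something is new, unique, unknown or untested is made for them only; others in the source may bear on it.

All numbers come from a functional assay on RAW264.7 cells (Mus musculus) for inhibition, with a stated time of 4 days; a lower number here means a stronger inhibitor, a higher number a weaker inhibitor.

compound 1 `COc1cc(/C=C/C(=O)c2cccc(-n3cc(C(C)(C)O)nn3)c2)ccc1O`: 19800 nM
compound 2 `COc1cc(/C=C/C(=O)c2cccc(-n3cc(-c4ccccc4)nn3)c2)ccc1O`: 16800 nM

For the measured compounds named here, compound 2 gives the lowest of the two numbers so far, but its nearest neighbour is compound 1, and the step of a 1.2-fold lower number from compound 1 to compound 2 (0.07 log units; within the scatter) lies within the scatter, so the two cannot be ordered against each other. Compound 2 therefore stands as one of two equivalent points, not as a distinguished one.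

Compound 3 `COc1cc(/C=C/C(=O)c2cccc(-n3cc(-c4ccc(C)cc4)nn3)c2)ccc1O` differs from compound 2 by methyl in place of hydrogen on an aromatic carbon. Going by the values given here, only one measured step exists, the one from compound 1 to compound 2, and it concerns a different change, the whole group on the aromatic carbon rather than a substituent on the phenyl; that step was within the scatter. Nothing measured speaks to a methyl in place of hydrogen on the phenyl itself, so there is no basis for expecting a move beyond the scatter in this assay. The expected step from compound 2 to compound 3 is a 1.1-fold lower number from compound 2 to compound 3 (0.05 log units; within the scatter), essentially flat. For compound 3 the estimate is 15000 nM, with a range of 6000 nM to 40000 nM.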

Compound 3, half-maximal inhibitory concentration: 15400 nM
Beside the measured number, compound 3's estimate is 1.0-fold (0.01 log units) below it; the range from low to high includes it.
By their numbers in this assay, from the lowest: compounds 3, 2 and 1 (each within the scatter of the next).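

In this assay a methyl in place of hydrogen on the phenyl, para to a large group, gives a 1.1-fold lower number from compound 2 to compound 3 (0.04 log units; within the scatter) and stays inside the scatter, so this position now has a direct reading: phenyl to 4-methylphenyl leaves the number unresolved from that of the unsubstituted phenyl. Adding the methyl also fails to separate the aryl series from the tertiary alcohol end of the set, since 4-methylphenyl in place of 1-hydroxy-1-methylethyl gives a 1.3-fold lower number from compound 1 to compound 3 (0.11 log units; within the scatter) and this too stays inside the scatter, leaving compounds 1, 2 and 3 as one level in this assay. No available evidence accounts for this flatness or bears on this result.

From the compounds shown here alone, whether an amine or a carboxylic acid in place of the methyl at this position, or a longer chain such as butyl, would move the number beyond the scatter remains open. Also open, going by these compounds, is whether a group on the phenyl at any other ring position, such as a fluorine or a methoxy, would read differently from the methyl in this assay on the same shared core.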